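The compounds below may be only part of what the source reports. "The series", "measured", "known", "first", "only" and "open" are said of these compounds alone.

Of the compounds shown here, three of one family have been tested in a functional assay on trachea (Cavia porcellus) (a higher number here means a weaker inhibitor, a lower number a stronger inhibitor), and a fourth awaits its measurement.

Compound 1, `CO[C@@]12CCN(C)C[C@H]1[C@H](c1ccc(Cl)cc1)C(C#N)=C(N)O2`, gives 10500 nM in this assay. Compound 2, `CCCN1CC[C@@]2(OC)OC(N)=C(C#N)[C@@H](c3ccc(Cl)cc3)[C@@H]2C1`, differs from it by ethyl in place of hydrogen on a saturated chain carbon bound to an amine nitrogen in a ring and gives 30300 nM; the change made a 2.9-fold higher number from compound 1 to compound 2 (0.46 log units; beyond the scatter). Compound 3, `CO[C@@]12CCN(C)C[C@H]1[C@H](c1ccc(F)cc1)C(C#N)=C(N)O2`, differs from compound 1 by fluoro in place of chloro on an aromatic carbon; in this assay compound 3 gives 19400 nM. Here the change made a 1.8-fold higher number from compound 1 to compound 3 (0.27 log units; within the scatter), so compound 1 and compound 3 cannot be set apart by this assay.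

Compound 4, `CCCN1CC[C@@]2(OC)OC(N)=C(C#N)[C@@H](c3ccc(F)cc3)[C@@H]2C1`, has not yet been measured. It differs from compound 3 by ethyl in place of hydrogen on a saturated chain carbon bound to an amine nitrogen in a ring, the same change that turned compound 1 into compound 2, at the same place in both. The two cores on which the change is made differ only by fluoro in place of chloro on an aromatic carbon. Going by the values given here, since this is the only earlier example of the change, the expectation for compound 4 rests on the step from compound 1 to compound 2, which was a 2.9-fold higher number from compound 1 to compound 2 (0.46 log units; beyond the scatter); a step of similar size is expected from compound 3 to compound 4, namely a 2.7-fold higher number from compound 3 to compound 4 (0.43 log units; beyond the scatter). On that basis compound 4 is expected to give about 52000 nM in this assay, most likely somewhere between 20000 nM and 130000 nM.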

Compound 4, half-maximal inhibitory concentration: 29600 nM
Compound 4: the middle estimate sits 1.8-fold (0.24 log units) above what was measured; low and high end bracket the measured number.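

In this assay, ethyl in place of hydrogen on a saturated chain carbon bound to an amine nitrogen in a ring, which turns methyl to propyl, gives a 1.5-fold higher number from compound 3 to compound 4 (0.18 log units; within the scatter), while fluoro in place of chloro on an aromatic carbon gives a 1.0-fold lower number from compound 2 to compound 4 (0.01 log units; within the scatter). Set beside its earlier example, the methyl to propyl change shows no difference between the two cores that this assay can detect: the same change on two cores in this assay, a 2.9-fold higher number (0.46 log units; beyond the scatter) from compound 1 to compound 2 and a 1.5-fold higher number (0.18 log units; within the scatter) from compound 3 to compound 4, 1.9-fold (0.28 log units) apart, within the scatter of two such steps. The fluoro for chloro change reads the same way, but this does not prove that either change has an identical effect on both cores, as only two pairs are available and a real difference smaller than the scatter would go unseen: the same change on two cores in this assay, a 1.8-fold higher number (0.27 log units; within the scatter) from compound 1 to compound 3 and a 1.0-fold lower number (0.01 log units; within the scatter) from compound 2 to compound 4, 1.9-fold (0.28 log units) apart, within the scatter of two such steps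

The compounds shown leave open whether a longer chain, such as butyl, or a benzyl group in that same place would follow the step from methyl to propyl. They also leave open whether bromo or methoxy on the aromatic carbon would fit with what is seen for chloro and fluoro.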